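Swapping the group on the carbonyl carbon of compound 3

A few compounds are considered here, and "the series" means these few. Any claim that something is new, unique, unknown or untested is made for them only; others in the source may bear on it.

In a functional assay on A20 cells (Mus musculus) for inhibition, with stated times of 1 h, 16 h and 24 h (on this read-out higher numbers stand for weaker inhibition and lower numbers for stronger inhibition), compound 3 `N#CC1(NC(=O)[C@@H]2C[C@@H](S(=O)(=O)c3ccccc3)C[C@H]2C(=O)N2CCC(O)CC2)CC1` gives 371 nM, the weakest inhibition of three related compounds. Compound 1 `N#CC1(NC(=O)[C@@H]2C[C@@H](S(=O)(=O)c3ccccc3)C[C@H]2C(=O)N2CC3CCC(C2)O3)CC1` gives 16 nM and compound 2 `CN1CCN(C(=O)[C@@H]2C[C@H](S(=O)(=O)c3ccccc3)C[C@H]2C(=O)NC2(C#N)CC2)CC1` gives 17 nM. The step linking those two is a 1.1-fold higher number from compound 1 to compound 2 (0.03 log units; within the scatter). The two steps up to the highest number are large: a 23-fold higher number from compound 1 to compound 3 (1.37 log units; beyond the scatter), and a 22-fold higher number from compound 2 to compound 3 (1.34 log units; beyond the scatter).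

Compound 4 `N#CC1(NC(=O)[C@@H]2C[C@@H](S(=O)(=O)c3ccccc3)C[C@H]2C(=O)N2CCS(=O)(=O)CC2)CC1` keeps the shared core and changes only the group on the carbonyl carbon: 1,1-dioxothiomorpholin-4-yl in place of 4-hydroxypiperidin-1-yl on a carbonyl carbon. For the measured compounds named here, no measurement yet covers the 1,1-dioxothiomorpholin-4-yl group, so the evidence is indirect. Compound 1 at 16 nM and compound 2 at 17 nM carry unlike groups yet give matching numbers, and only the 4-hydroxypiperidin-1-yl group stands apart. A move towards stronger inhibition is therefore expected, though probably smaller than those large steps. The expected step is a 4.6-fold lower number from compound 3 to compound 4 (0.67 log units; beyond the scatter). For compound 4 the estimated value is 80 nM, with an expected range of 20 nM to 300 nM.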

Compound 4, half-maximal inhibitory concentration: 816 nM
For compound 4 the middle estimate is 10-fold (1.01 log units) below the measured one, outside the stated range (above it).
By their numbers in this assay, from the lowest: compounds 1 and 2 (each within the scatter of the next); then compound 3; then compound 4.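

At this carbonyl carbon, the 1,1-dioxothiomorpholin-4-yl group does not bring back the stronger inhibition: in this assay the change brings a modest rise (a 2.2-fold higher number from compound 3 to compound 4 (0.34 log units; beyond the scatter)) and leaves a wide gap to the two strongest compounds (a 48-fold higher number from compound 2 to compound 4 (1.68 log units; beyond the scatter); a 51-fold higher number from compound 1 to compound 4 (1.71 log units; beyond the scatter)). Compound 1, compound 2 and compound 4 each carry a six-membered non-aromatic ring with two hetero atoms here, yet compound 4 gives the weakest inhibition of the four, so that ring count alone does not sort these numbers. No measurement shown here accounts for the difference between these groups.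

The compounds shown leave open how a group without a ring, such as dimethylamino, would read on this carbonyl carbon. They also leave open how morpholin-4-yl, or a piperidin-1-yl ring bearing a carboxylic acid instead of the hydroxyl, would compare.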